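A few compounds are considered here, and "the series" means these few. Any claim that something is new, unique, unknown or untested is made for them only; others in the source may bear on it.

In an ADME assay on L02 cells (Homo sapiens) for cytotoxicity, read by MTT assay, with a stated time of 24 h (a higher number here means that more compound is tolerated, a lower number that less compound is tolerated), compound 3 `O=c1[nH]cc(S(=O)(=O)Nc2ccc(-c3cn(-c4cccc(F)c4)nn3)cc2)c(=O)[nH]1` gives "not toxic" (no number reported), which is no single number. Compound 1 `Cc1ccccc1-n1cc(-c2ccc(NS(=O)(=O)c3c[nH]c(=O)[nH]c3=O)cc2)nn1` likewise gives "not toxic" (no number reported) in this assay, so compound 3 stands beside one further entry without a number. For the measured compounds named here, compound 2 `Cc1cccc(-n2cc(-c3ccc(NS(=O)(=O)c4c[nH]c(=O)[nH]c4=O)cc3)nn2)c1` gives 39000 nM in this assay and is the only compound of the set with a figure. Compound 4 `O=c1[nH]cc(S(=O)(=O)Nc2ccc(-c3cn(-c4ccccc4Cl)nn3)cc2)c(=O)[nH]1` has not yet been measured in this assay. It differs from compound 3 in one place: 2-chlorophenyl in place of 3-fluorophenyl on an aromatic nitrogen. Going by the values given here, no step between measured compounds covers this change, so its size cannot be read from the data; the expectation is that compound 4 is tolerated in the same broad range as the compounds already measured, with no shift beyond the usual scatter. For compound 4 in this assay the estimate is 50000 nM, in the range 20000 nM to 150000 nM.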

Compound 4, half-maximal cytotoxic concentration: 19300 nM
Beside the measured number, compound 4's estimate is 2.6-fold (0.41 log units) above it; measured number below the stated range.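

In this assay, 2-chlorophenyl in place of 3-methylphenyl on the aromatic nitrogen gives a 2.0-fold lower number from compound 2 to compound 4 (0.31 log units; beyond the scatter), so a change at this position can move the number beyond the scatter. Compound 3, with 3-fluorophenyl, gives "not toxic" (no number reported), while compound 4 has a figure, so this single change separates an entry without a number from one with a number. No measurement at hand accounts for the shift. Going by these compounds, whether the chlorine or its place on the ring matters remains open, and so does the effect of an amine or a carboxylic acid on this phenyl ring.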